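Swapping the outer group on a long-lived compound

The source may report more compounds than this note shows. Statements on the series, on what has been measured and on what is new or still open speak of the compounds shown alone.

Measured in an ADME assay (liver, Mus musculus) for metabolic stability, using microsomes; on this read-out lower numbers stand for a shorter-lived compound and higher numbers for a longer-lived compound:
Compound 1 `CCc1nc2ccc(Cl)cn2c1C(=O)NCc1ccc(-c2ccc(C#N)cc2)cc1`: > 1 h (a limit)
Compound 2 `CCc1nc2ccc(Cl)cn2c1C(=O)NCc1ccc(-c2ccc(C)cc2)cc1`: 0.677 h
Compound 3 `CCc1nc2cc(Cl)ccn2c1C(=O)NCc1ccc(-c2ccc(C(=O)O)cc2)cc1`: > 2 h (a limit)

In this assay compound 3 stands at > 2 h, which is a limit and not a number. Compound 4 `CCc1nc2cc(Cl)ccn2c1C(=O)NCc1ccc(N2CCC(Cl)CC2)cc1` keeps the core of compound 3 and changes one group: 4-chloropiperidin-1-yl in place of 4-carboxyphenyl on an aromatic carbon. In short, 4-chloropiperidin-1-yl comes in place of 4-carboxyphenyl on an aromatic carbon.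

Among the compounds with values here, no measured step makes this swap. The only one available is an at least 1.4-fold lower number from compound 1 to compound 2 (0.16 log units; that floor lies within the scatter), a different change, so it offers weak guidance. Compound 2 lacks 4-carboxyphenyl and gives 0.677 h, which suggests a value nearer that number. Compound 1 also lacks that group and gives > 1 h, a limit, so the expected range stays wide.

An expected step of an at least 2.5-fold lower number from compound 3 to compound 4 (0.39 log units; beyond the scatter) is estimated, towards a shorter-lived compound. For compound 4 the expected half-life is 0.8 h, with an estimated range from 0.25 h to 2.5 h.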

Compound 4, half-life: 0.0867 h
Estimate against measurement, compound 4: 9.2-fold (0.97 log units) above; measured number below the stated range.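

In this assay, replacing the whole 4-carboxyphenyl group on this aromatic carbon, para to a large group, gives an at least 23-fold lower number from compound 3 to compound 4 (1.36 log units; beyond the scatter), so this position can carry a change that leaves a very short-lived compound. The earlier step altered only the small group on the outer ring and gave an at least 1.4-fold lower number from compound 1 to compound 2 (0.16 log units; that floor lies within the scatter), which showed nothing of this size. The true step could be larger still, because compound 3 stands at a limit: the limit of > 2 h in this assay, at which 1 of the 4 values shown sits.

The swap removes the carboxylic acid and the aromatic ring and adds the chlorine and the non-aromatic ring all at once, so the compounds shown cannot tell which of these parts matters. A plain piperidin-1-yl without the chlorine, or a phenyl ring carrying an amine in place of the acid, would help to separate them.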